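The compounds below may be only part of what the source reports. "The series", "measured", "known", "first", "only" and "open" are said of these compounds alone.

Working notes on the series. Within the data shown here, compound 1 `O=C(O)c1cc(-c2cccc(COc3ccc4c(c3)CN(C3CCCC3)C4=O)c2)ccc1O` is the only member with a number in an assay on HEK293 cells for positive allosteric modulation of metabotropic glutamate receptor 2 (Rattus norvegicus), read by thallium flux; a lower number here means a smaller maximal response, a higher number a larger maximal response: compound 1 gives 90.1%. Among the measured compounds shown here, compound 2 `O=C1c2ccc(OCc3cccc(-c4ccc(C(F)(F)F)cc4F)c3)cc2CN1C1CCCC1` has no result in this assay, its entry reading "not determined" (no result reported), so there is no number to place it against compound 1 and no step from it can be sized. The next member, compound 3 `COc1ccc(-c2cccc(COc3ccc4c(c3)CN(C3CCCC3)C4=O)c2)cc1C(=O)O`, differs from compound 2 at one position: 3-carboxy-4-methoxyphenyl in place of 2-fluoro-4-(trifluoromethyl)phenyl on an aromatic carbon. For the measured compounds named here, since compound 2 carries no value in this assay, no direction and no size of change can be read for this replacement from the two compounds themselves; the only anchor is compound 1, whose structure stands much nearer to compound 3 than compound 2 does. On that basis the maximal response of compound 3 in this assay is expected to resemble the value of compound 1, because compound 1 gives 90.1%. The estimate for compound 3 in this assay is 85%, with a range from 60% to 105%.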

Compound 3, largest response reached (reported as percent of maximum), in percent of the reference or control that the assay uses: 78%
Beside the measured number, compound 3's estimate is 7 percentage points above it; measured number inside the range.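

In this assay, among these compounds, methyl in place of hydrogen on an oxygen on an aromatic ring gives a number 12.1 percentage points lower from compound 1 to compound 3 (beyond the scatter) and this is the first change whose size can be read. The oxygen substituent on this ring therefore affects the maximal response, yet with the methyl in place compound 3 still gives 78% and so keeps much of the response. The step from compound 2 to compound 3 cannot be read, and nothing at hand bears on the reason for the lower response.

Going by these compounds, whether a longer chain such as ethyl on that oxygen would lower the response further, or an amine in its place would recover it, remains open. Among the compounds shown here, the contribution of the carboxylic acid alone also remains open, with no measured pair isolating it.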